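The source may report more compounds than this note shows. Statements on the series, on what has been measured and on what is new or still open speak of the compounds shown alone.

Measured so far:
compound 1 `COc1ccc(-c2ccc(-c3ccc(C(=N)N)o3)o2)cc1` — 71.7%
compound 2 `N=C(N)c1ccc(-c2ccc(-c3ccc(Cl)cc3)s2)s1` — 81.7%
compound 3 `COc1cccc(-c2ccc(-c3ccc(C(=N)N)s3)s2)c1` — 79%

In an ADME assay on cells (Erythrocyte, Homo sapiens) for activation, read by hemolysis, with a stated time of 30 min, tested at 10 mM (on this read-out higher numbers stand for a stronger effect at the one concentration tested and lower numbers for a weaker effect), compound 1 gives 71.7%, the smallest of the three numbers. The gap to compound 3 and the gap to compound 2 both fall within the usual scatter of repeated runs, so the three numbers cannot be told apart; no ranking among them is claimed. Going by the values given here, compound 2 and compound 3 carry a different core from compound 1, and no step between compounds that differ in one place alone has been measured, so the series gives no direct handle on any single change.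

Compound 4 `N=C(N)c1ccc(-c2ccc(-c3ccc(F)cc3)o2)o1` is the next compound in this assay. It differs from compound 1 as follows: fluoro in place of methoxy on an aromatic carbon. Among the compounds with values here, with no measured step of this kind to lean on, and with all three numbers so far sitting inside one scatter band, a step in this assay that stays within the scatter is expected, in neither direction beyond it. For compound 4 the expected value is 74%, with a range from 60% to 88%. The step this estimate implies, a number 2.3 percentage points higher from compound 1 to compound 4 (within the scatter), is expected to be no larger than the scatter.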

Compound 4, a percentage reported as activity, at one concentration (the size of the read-out at that concentration, not a potency): 90%
Compound 4: the middle estimate sits 16 percentage points below what was measured, and the stated range ends below it.
By their numbers in this assay, from the lowest: compounds 1, 3, 2 and 4 (each within the scatter of the next, the first and the last beyond it).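

Going by these compounds alone, on the core of compound 1, the place on the six-membered aromatic ring of carbon only, para to a large group, gives the first single-change reading: in this assay, fluoro in place of methoxy on an aromatic carbon gives a number 18.3 percentage points higher from compound 1 to compound 4 (beyond the scatter). Within the data shown here, this place is therefore not silent, since one swap here moves the number beyond the scatter, which the three earlier compounds, with no single-place step among them, could not show. No measurement at hand speaks to why the number moves.

The compounds shown do not tell whether the step belongs to fluoro itself or to the departure of methoxy, and a methyl or an amine at this place would bear on that. On these data alone, whether the same change gives a like step on the core of compound 2 also stays open.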